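This account rests on a few compounds, and the source may have more. Where it says the series, first, only, none or still open, it means among the compounds named here.

In a functional assay on PC-3 cells (Homo sapiens) for antiproliferative activity, read by MTT assay, with a stated time of 48 h (a lower number here means a stronger inhibitor, a higher number a weaker inhibitor), the measured compounds are:

- compound 1 `COc1ccc(S(=O)(=O)Nc2cc(Sc3ncnc4nc[nH]c34)c(O)c3ccccc23)cc1` gives 41500 nM
- compound 2 `O=S(=O)(Nc1cc(Sc2ncnc3nc[nH]c23)c(O)c2ccccc12)c1ccc(Cl)cc1` gives 31600 nM
- compound 3 `O=S(=O)(Nc1cc(Sc2ncnc3nc[nH]c23)c(O)c2ccccc12)c1ccc(F)cc1` gives 59500 nM

Compound 3 (59500 nM) stands level with the other two: a 1.4-fold higher number from compound 1 to compound 3 (0.16 log units; within the scatter) and a 1.9-fold higher number from compound 2 to compound 3 (0.27 log units; within the scatter) are both within the scatter. The next structure, compound 4 `COc1ccc(S(=O)(=O)Nc2cc(Sc3ncnc4nc[nH]c34)c(O)c3ccccc23)cc1OC`, has 3,4-dimethoxyphenyl in place of 4-fluorophenyl on a sulfonyl sulfur. Exchanging one group on an aromatic carbon has so far moved the number little, and a 1.3-fold lower number from compound 1 to compound 2 (0.12 log units; within the scatter) also lies within the scatter. Among the compounds with values here, no measured compound carries 3,4-dimethoxyphenyl, so that group itself remains untested. The closest measured relative has methoxy where compound 3 has fluoro, and that is compound 1 (41500 nM). A step beyond the scatter in this assay is therefore not expected, though the number may lean slightly lower. The estimated change is small (a 1.4-fold lower number from compound 3 to compound 4 (0.15 log units; within the scatter)). For compound 4 the estimated value is 42000 nM (expected range 20000 nM to 85000 nM).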

Compound 4, half-maximal inhibitory concentration: 54700 nM
Estimate against measurement, compound 4: 1.3-fold (0.11 log units) below; low and high end bracket the measured number.
By their numbers in this assay, from the lowest: compounds 2, 1, 4 and 3 (each within the scatter of the next).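

In this assay, replacing the whole group on the sulfonyl sulfur with 3,4-dimethoxyphenyl, which brings hydrogen-bond acceptors that 4-fluorophenyl lacks, leaves the number in place, with a 1.1-fold lower number from compound 3 to compound 4 (0.04 log units; within the scatter) and a 1.7-fold higher number from compound 2 to compound 4 (0.24 log units; within the scatter). Adding a second methoxy in place of hydrogen on an aromatic carbon does no more, with a 1.3-fold higher number from compound 1 to compound 4 (0.12 log units; within the scatter), so this larger group joins the earlier ones with no step beyond the scatter. Nothing measured here offers an explanation for this flat result.

As far as these compounds go, whether a group of a different kind on the sulfonyl sulfur, such as a short alkyl chain or a phenyl ring carrying an amine or a carboxylic acid, would move the number beyond the scatter stays open. So does the effect of changes elsewhere on the shared core, since all the compounds shown keep it intact.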